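The compounds below may be only part of what the source reports. "The series", "measured", "known", "first", "only" and "open" are said of these compounds alone.

Compound 3 `Cc1ccc(N2CCN(CCNC(=O)c3ccncc3)CC2)c(C)c1` gives the lowest number of the three measured in a functional assay for antagonist activity at Adrenergic receptor alpha-1 (Rattus norvegicus) (a higher number here means weaker binding, a lower number tighter binding), at 85.1 nM. Compound 1 `Cc1ccc(N2CCN(CCNC(=O)c3cccnc3)CC2)cc1` gives 295 nM in this assay and compound 2 `Cc1ccc(N2CCN(CCNC(=O)c3ccco3)CC2)cc1` gives 339 nM; both sit beyond the scatter from compound 3. Within the data shown here, the only measured step, a 1.1-fold higher number from compound 1 to compound 2 (0.06 log units; within the scatter), concerns the aryl amide and not the ring on the piperazine. Compound 4 `Cc1ccc(N2CCN(CCNC(=O)c3ccncc3)CC2)cc1` differs from compound 3 by hydrogen in place of methyl on an aromatic carbon. Among the measured compounds shown here, no measured pair covers this change; compound 1, which also carries 4-methylphenyl, gives 295 nM with another amide group, and compound 2, which carries 4-methylphenyl as well, gives 339 nM. Compound 4 is therefore expected to give a weaker number, about a 2.9-fold higher number from compound 3 to compound 4 (0.47 log units; beyond the scatter), with an estimate of 250 nM in a range from 100 nM to 650 nM.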

Compound 4, dissociation constant: 316 nM
Estimate against measurement, compound 4: 1.3-fold (0.10 log units) below; low and high end bracket the measured number.
By their numbers in this assay, from the lowest: compound 3; then compounds 1, 4 and 2 (each within the scatter of the next).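

In this assay, among these compounds, the change from 2,4-dimethylphenyl to 4-methylphenyl gives a 3.7-fold higher number from compound 3 to compound 4 (0.57 log units; beyond the scatter) as the first measured step at this position, so in this pair the methyl goes with the tighter binding. With 4-methylphenyl held constant, the amide group makes no difference beyond the scatter: a 1.1-fold higher number from compound 1 to compound 4 (0.03 log units; within the scatter) and a 1.1-fold lower number from compound 2 to compound 4 (0.03 log units; within the scatter) are the steps to pyridin-4-yl. No evidence on hand bears on this result.

From the compounds shown here alone, whether the methyl step carries over to the pyridin-3-yl and furan-2-yl amides remains open. So does the effect of a methoxy group or chlorine in place of this methyl.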